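Adding an iodo group to compound 1

The source may hold more compounds than are shown below. What is called first, only, known or untested is meant among the compounds shown, and "the series" means these compounds.

Going by the values given here, in a functional assay on T47D cells (Breast, Homo sapiens) for inhibition (a lower number here means a stronger inhibitor of growth, a higher number a weaker inhibitor of growth), compound 1 (`Nc1ccc(-c2nc3cc(F)ccc3s2)cc1`) gives 260 nM, the higher of the two numbers measured so far, which makes it the weaker growth inhibitor. Compound 2 (`Cc1cc(-c2nc3cccc(F)c3s2)ccc1N`) differs from it in more than one place and gives 20 nM. Compound 3 (`Nc1ccc(-c2nc3cc(F)ccc3s2)cc1I`) has iodo in place of hydrogen on an aromatic carbon of compound 1, ortho to an amino group (iodo in place of hydrogen on an aromatic carbon). Among the compounds with values here, compound 2 also carries a group ortho to an amino group, and with compound 2 at 20 nM as the only guide, a lower number is expected. The estimated step is a 4.3-fold lower number from compound 1 to compound 3 (0.64 log units; beyond the scatter), beyond the scatter. For compound 3, the expected value is 60 nM, within an estimated range of 12 nM to 300 nM.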

Compound 3, concentration for 50% growth inhibition: 130 nM
The estimate for compound 3 lay 2.2-fold (0.34 log units) below the measured number, within the range that was stated.
By their numbers in this assay, from the lowest: compound 2; then compounds 3 and 1 (each within the scatter of the next).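

Going by these compounds alone, compound 3 gives the first reading of a single change: iodo in place of hydrogen on this aromatic carbon, ortho to an amino group, gives a 2.0-fold lower number from compound 1 to compound 3 (0.30 log units; within the scatter) in this assay. The two compounds therefore cannot be told apart in this assay, so this one heavy atom at this place leaves growth inhibition within the usual scatter. No measured property bears on this result.

Going by these compounds, whether a chloro or methoxy group at the same place would separate from compound 1 remains open. So does what other single changes to the core of compound 1 would do.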